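The source may hold more compounds than are shown below. What is called first, only, known or untested is meant among the compounds shown, and "the series" means these compounds.

Compound 1 `CC(=O)c1ccc(/C=C(/Sc2ccc(C)cc2)C(=O)c2ccc(Br)cc2)cc1`: 50000 nM
Compound 2 `O=C(/C(=C\c1ccc(O)cc1O)S(=O)(=O)c1ccccc1Br)c1ccc(Br)cc1`: > 100000 nM
Compound 3 `Cc1ccc(CS/C(=C/c2ccc(O)c(O)c2O)C(=O)c2ccc(Cl)cc2)cc1`: 50000 nM

Of the compounds shown here, three have been tested in a functional assay on DU-145 cells (Homo sapiens) for inhibition, read by trypan blue exclusion, with a stated time of 96 h; a lower number here means a stronger inhibitor of growth, a higher number a weaker inhibitor of growth. Compound 1 gives 50000 nM and compound 3 gives 50000 nM in this assay, and these two values sit within the usual scatter of each other, so neither can be called the weaker or the stronger. For compound 2 this assay reports only a limit, > 100000 nM, and not a number. That limit is the limit of > 100000 nM in this assay, at which 1 of the 3 values shown sits. For the measured compounds named here, compound 2 therefore stands at the edge of what this assay can report, and no sized step connects it to compound 1 or compound 3.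

Compound 4 `O=C(/C(=C\c1ccc(Br)cc1)S(=O)(=O)c1ccccc1Br)c1ccc(Br)cc1` has not yet been measured in this assay. It differs from compound 2 in a single place: 4-bromophenyl in place of 2,4-dihydroxyphenyl on a double-bonded chain carbon bound to a double-bonded chain carbon. Going by the values given here, no pair of measured compounds differing in one place is available here, so no measured step guides the expectation for this change. Given that, the step of an at least 1.2-fold lower number from compound 2 to compound 4 (0.09 log units; that floor lies within the scatter) is expected to be small, with no direction claimed beyond the scatter. Compound 4 is expected to give about 80000 nM in this assay, within a range from 30000 nM to 200000 nM, and there is a fair chance that this assay again reports only a limit.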

Compound 4, concentration for 50% growth inhibition: 1000 nM
The estimate for compound 4 lay 80-fold (1.90 log units) above the measured number; the whole stated range lies above it.
By their numbers in this assay, from the lowest: compound 4; then compounds 1 and 3 (each within the scatter of the next). At a limit, above all of these: compound 2.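

Putting 4-bromophenyl in place of 2,4-dihydroxyphenyl, on a double-bonded chain carbon bound to a double-bonded chain carbon, gives an at least 100-fold lower number from compound 2 to compound 4 (2.00 log units; beyond the scatter) in this assay. For the compounds shown here, this is the first direct evidence about this position, since the earlier compounds offered no pair differing in one place, and it shows that a single change of group here can separate a compound with a measured growth inhibition from one with no number at all, on an otherwise shared core. For compound 2 the assay gives a limit and not a number, so the step has only a lower bound: the limit of > 100000 nM in this assay, at which 1 of the 4 values shown sits.

The change removes the hydrogen-bond donors and acceptors of the 2,4-dihydroxyphenyl group and brings in a bromine, and this one pair cannot tell whether losing the former, gaining the latter or both lie behind the step. A plain phenyl or a 4-aminophenyl at the same place would help separate these possibilities, while compounds 1 and 3 differ from compound 4 in more than one place and so say nothing about it.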